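The source may hold more compounds than are shown below. What is called first, only, known or untested is meant among the compounds shown, and "the series" means these compounds.

Compound 1 `O=C1CN(/N=C/c2ccc(-c3cccc(C(F)(F)F)c3)o2)C(=O)N1`: 647 mg/kg
Compound 2 `O=C1NC(=O)N(/N=C/c2ccc(-c3ccc([N+](=O)[O-])cc3)o2)C1O`: > 1000 mg/kg (a limit)

Among the compounds with values here, in a functional assay on the whole organism for activation, with Mus musculus as the target, with a stated time of 60 min (on this read-out higher numbers stand for an effect only at larger amounts of compound and lower numbers for an effect already at smaller amounts), compound 1 gives 647 mg/kg, the only plain number among the values here. Compound 2 reaches only (the limit of > 1000 mg/kg in this assay, at which 1 of the 2 values shown sits), which is a limit of the assay and not a number. Compound 3 `O=C1NC(=O)N(/N=C/c2ccc(-c3cccc(C(F)(F)F)c3)o2)C1O` has not yet been measured. It differs from compound 1 in a single place: hydroxy in place of hydrogen on a saturated ring carbon. Within the data shown here, no step between two measured compounds is available, so the size of this change cannot be read from any pair here. Compound 2 also carries a hydroxy group on its saturated ring carbon, but the rest of its structure differs from compound 1, so its limit says little about the hydroxy group alone. For compound 3 a modest shift toward larger doses is expected, a 1.3-fold higher number from compound 1 to compound 3 (0.12 log units; within the scatter), possibly within the scatter. Compound 3 is therefore estimated at 850 mg/kg, between 400 mg/kg and 1000 mg/kg.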

Compound 3, dose for half-maximal effect: 166 mg/kg
For compound 3 the middle estimate is 5.1-fold (0.71 log units) above the measured one; measured number outside the range, below it.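

In this assay, putting hydroxy in place of hydrogen on this saturated ring carbon, which turns 2,4-dioxoimidazolidin-1-yl into 5-hydroxy-2,4-dioxoimidazolidin-1-yl, gives a 3.9-fold lower number from compound 1 to compound 3 (0.59 log units; beyond the scatter). Within the data shown here, this is the first readable step at this position, and it shows that one added oxygen here is enough to move the effect to smaller doses by more than the usual scatter. Nothing measured here gives a reason for this shift.

Steps involving compound 2 cannot be read, and whether hydroxy does the same with a different group on the far end of the molecule stays open, as compound 2 gives a limit and not a number: the limit of > 1000 mg/kg in this assay, at which 1 of the 3 values shown sits. Also open is how a methoxy group, an amine or a longer chain would fare on the same ring carbon.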